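Benzyl-to-hydroxyl swap on the side chain of compound 1

A few compounds are considered here, and "the series" means these few. Any claim that something is new, unique, unknown or untested is made for them only; others in the source may bear on it.

Measured so far in a functional assay on aorta (Rattus norvegicus); a higher number here means a weaker inhibitor, a lower number a stronger inhibitor:
compound 1 `O=c1ccc(CCOCc2ccccc2)nn1Cc1ccccc1`: 32300 nM
compound 2 `Cn1nc(CCOCc2ccccc2)ccc1=O`: > 100000 nM
compound 3 `Cn1nc(CO)ccc1=O`: > 100000 nM

Among the compounds with values here, compound 1 holds the only number in this assay. For compound 2 the value is a limit of the assay. For compound 3 the value is likewise a limit of the assay, so these two show no difference between them. Within the data shown here, the one measured step, an at least 3.0-fold higher number from compound 1 to compound 2 (0.49 log units; beyond the scatter), removed a phenyl and weakened inhibition, with the result at the limit of > 100000 nM in this assay, at which 2 of the 3 values shown sit.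

Compound 4 `O=c1ccc(CCCO)nn1Cc1ccccc1` differs from compound 1 by hydroxymethyl in place of benzyloxy on a saturated chain carbon, two bonds along the chain from an aromatic carbon. Among the measured compounds shown here, no measured step covers this change, but it too removes a phenyl, and the step from compound 1 to compound 2 suggests weakening. Compound 4 is therefore expected to give 100000 nM (range 40000 nM to 300000 nM). The expected step is a 3.1-fold higher number from compound 1 to compound 4 (0.49 log units; beyond the scatter), with a fair chance that only a limit is reported.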

Compound 4, half-maximal inhibitory concentration: > 100000 nM
Compound 4 ended at the assay's limit (the forecaster's own chance of this, stated with the estimate: 55%); the middle value lies on the limit itself.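

In this assay, the benzyloxy on the side chain matters even with the benzyl on the ring nitrogen kept: hydroxymethyl in its place gives an at least 3.0-fold higher number from compound 1 to compound 4 (0.49 log units; beyond the scatter). Removing the phenyl from either end of compound 1, as in compound 2 or compound 4, therefore loses the measurable value. The full size of the loss cannot be read: the limit of > 100000 nM in this assay, at which 3 of the 4 values shown sit.

Still open, as far as these compounds go, is whether the phenyl or the ether oxygen of benzyloxy carries the effect, which a phenylalkyl chain without the oxygen would separate. Also open, from the compounds shown here alone, is whether an amine or a carboxylic acid at this place restores any inhibition.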